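The source may report more compounds than this note shows. Statements on the series, on what has been measured and on what is new or still open speak of the compounds shown alone.

For the measured compounds named here, compound 1 `CC[C@@H](Nc1c(C#N)c(-c2ccc(-c3ncccc3C)cc2)nc2cnccc12)C(N)=O` gives 2 in a physicochemical assay for lipophilicity, read by HPLC, at pH 7.5 (a higher number here means a more lipophilic compound, a lower number a more polar compound), the lowest of the three numbers so far: compound 2 `CCOc1ccccc1-c1ccc(-c2nc3cnccc3c(C[C@H](C)C(N)=O)c2C#N)cc1` gives 3 in this assay, and compound 3 `CCOc1ccccc1-c1ccc(-c2nc3cnccc3c(N[C@H](CC(C)C)C(N)=O)c2C#N)cc1` gives 3.4. Going by the values given here, the only measured step, a number 0.40 log units higher from compound 2 to compound 3 (beyond the scatter), concerns the side chain on the core and not the aryl ring, so no measured step bears directly on the change that leads to compound 4 `CC[C@@H](Nc1c(C#N)c(-c2ccc(-c3ccccc3C(F)(F)F)cc2)nc2cnccc12)C(N)=O`, namely (2-(trifluoromethyl)phenyl in place of 3-methylpyridin-2-yl on an aromatic carbon). With nothing of the same kind to lean on, the direction rests on the structural change alone. The step is expected to be a number 1.00 log units higher from compound 1 to compound 4 (beyond the scatter). Compound 4 is therefore estimated at 3, within a range from 2.4 to 3.6.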

Compound 4, distribution coefficient: 3.1
Compound 4: the middle estimate sits 0.10 log units below what was measured; the range from low to high includes it.
By their numbers in this assay, from the lowest: compound 1; then compounds 2, 4 and 3 (each within the scatter of the next, the first and the last beyond it).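

In this assay, for the compounds shown here, the first measured step at this position, on an aromatic carbon para to a large group, is large: a number 1.10 log units higher from compound 1 to compound 4 (beyond the scatter) with 2-(trifluoromethyl)phenyl in place of 3-methylpyridin-2-yl. The change replaces the ring nitrogen and the methyl group together, so this single pair does not separate their shares in the step. No measurement here accounts for its size. From the compounds shown here alone, whether a plain phenyl or a 2-methylphenyl group would lie nearer compound 1 or compound 4 remains open. So does whether the step would hold with the side chain of compound 2 or compound 3.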